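This account rests on a few compounds, and the source may have more. Where it says the series, first, only, none or still open, it means among the compounds named here.

Measured so far in an ADME assay on microsomes from liver (Rattus norvegicus) for metabolic stability, with a stated time of 60 min, tested at 1 uM; a lower number here means that less of the compound is left, a higher number that more of the compound is left:
- compound 1 `CNc1nc2c(-c3ccnc(OC)c3)cnn2cc1OC`: 74%
- compound 2 `COc1cc(-c2cnn3cc(OC)c(C(C)C)nc23)ccn1`: 14%
- compound 3 `COc1cn2ncc(-c3ccnc(OC(C)C)c3)c2nc1-c1cnn(C)c1`: 50%

Compound 3, at 50%, is second highest of the three. Compound 1 lies higher at 74% and compound 2 lower at 14%, both gaps beyond the scatter.

The next compound is compound 4 `COc1cn2ncc(-c3ccnc(OC(C)(C)C)c3)c2nc1-c1cnn(C)c1`, where isopropoxy becomes tert-butoxy: methyl in place of hydrogen on a saturated chain carbon bound to an oxygen on an aromatic ring and two saturated chain carbons. The added methyl sits on a saturated chain carbon bound to an oxygen on an aromatic ring and two saturated chain carbons.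

Among the compounds with values here, only one measured step is available: a number 60 percentage points lower from compound 1 to compound 2 (beyond the scatter). This large step, beyond the scatter, involves different groups in a different place, so its size does not carry over to the present change. Within the data shown here, it shows only that a single group exchange can move this assay substantially, which argues for a wide range. Among the measured compounds shown here, no measured step tests isopropoxy against tert-butoxy, so the direction is poorly defined.

With the value of compound 3 at 50% as the anchor, a small change is expected: a number 5 percentage points lower from compound 3 to compound 4 (within the scatter), not expected to lie beyond the scatter. Compound 4 is estimated at 45%, with an expected range of 20% to 70%.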

Compound 4, percent of the compound remaining: 61%
Beside the measured number, compound 4's estimate is 16 percentage points below it; the range from low to high includes it.
By their numbers in this assay, from the lowest: compound 2; then compound 3; then compound 4; then compound 1.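

In this assay, within the data shown here, the exchange of isopropoxy for tert-butoxy gives a number 11 percentage points higher from compound 3 to compound 4 (beyond the scatter) and is the first measured step at this place, a saturated chain carbon bound to an oxygen on an aromatic ring and two saturated chain carbons. Among these compounds, a single added methyl, one heavy atom with no hydrogen-bond donor or acceptor, is thus enough to move the read-out beyond the scatter, and the larger branched group goes with the higher number in this pair, though the pair gives only one step in one direction on one core. Nothing available explains why the added methyl raises the number.

Open, as far as these compounds go, is how far this direction extends at the same oxygen: methoxy, cyclopropoxy or a longer chain such as n-butoxy on the core shared by compound 3 and compound 4 would show whether branching or size tracks with the read-out, and an amine in place of the ether oxygen would test the link itself. Also open, from the compounds shown here alone, is whether the same exchange gives a step of similar size on the cores of compound 1 and compound 2.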